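From 3-(4-methylphenoxy)propyl to Butyl on a Shared Core

The source may report more compounds than this note shows. Statements on the series, on what has been measured and on what is new or still open speak of the compounds shown alone.

In a functional assay on HCT-116 cells (Homo sapiens) for antiproliferative activity, read by MTT assay, with a stated time of 48 h (on this read-out lower numbers stand for stronger inhibition of growth and higher numbers for weaker inhibition of growth), compound 1 `Cc1ccc(-c2cnc(N(Cc3ccc(C(=O)NO)cc3)CC(C)C)s2)cc1` gives 5900 nM as its reading. Compound 2 `CCCCCCCCN(Cc1ccc(C(=O)NO)cc1)c1ncc(-c2ccc(C)cc2)s1` gives 6500 nM on the same read-out, and the change (a 1.1-fold higher number from compound 1 to compound 2 (0.04 log units; within the scatter)) does not separate the two. Compound 3 `Cc1ccc(OCCCN(Cc2ccc(C(=O)NO)cc2)c2ncc(-c3ccc(C)cc3)s2)cc1` reads 12600 nM and stands apart from compound 1 alone: the modest step of a 2.1-fold higher number from compound 1 to compound 3 (0.33 log units; beyond the scatter) contrasts with the step of a 1.9-fold higher number from compound 2 to compound 3 (0.29 log units; within the scatter), which remains within the scatter.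

Compound 4 `CCCCN(Cc1ccc(C(=O)NO)cc1)c1ncc(-c2ccc(C)cc2)s1` has not yet been measured. It differs from compound 3 as follows: methyl in place of 4-methylphenoxy on a saturated chain carbon, three bonds along the chain from a nitrogen on an aromatic ring.

Going by the values given here, the closest precedent is the exchange of pentyl for 4-methylphenoxy at this same place (a 1.9-fold higher number from compound 2 to compound 3 (0.29 log units; within the scatter)). Run in reverse, it points to a lower number of similar size. The step between compound 1 and compound 2 (a 1.1-fold higher number from compound 1 to compound 2 (0.04 log units; within the scatter)) gives no sign that the length of a plain chain matters much here, though only those two compounds bear on that. The estimate therefore expects a 2.0-fold lower number from compound 3 to compound 4 (0.30 log units; within the scatter), close to the edge of the scatter. Compound 4 is expected to read 6300 nM, with an estimated range from 3200 nM to 12000 nM in this assay.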

Compound 4, concentration for 50% growth inhibition: 8780 nM
For compound 4 the middle estimate is 1.4-fold (0.14 log units) below the measured one; the measured number falls inside the stated range.
By their numbers in this assay, from the lowest: compounds 1, 2, 4 and 3 (each within the scatter of the next, the first and the last beyond it).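

Replacing 4-methylphenoxy with methyl on a saturated chain carbon, three bonds along the chain from a nitrogen on an aromatic ring, gives a 1.4-fold lower number from compound 3 to compound 4 (0.16 log units; within the scatter) in this assay, so this exchange, like the earlier one with pentyl, does not separate the compounds it joins. Compound 4, with its butyl chain, also sits close to the other two compounds, with a 1.4-fold higher number from compound 2 to compound 4 (0.13 log units; within the scatter) and a 1.5-fold higher number from compound 1 to compound 4 (0.17 log units; within the scatter), so the lack of separation among plain chains now rests on three compounds rather than two. Going by these compounds alone, the step of a 2.1-fold higher number from compound 1 to compound 3 (0.33 log units; beyond the scatter) remains the only one beyond the scatter, and compound 4 adds no second such step, leaving the 3-(4-methylphenoxy)propyl group with no consistent separation from the plain chains. No supporting measurement is available to explain these readings.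

The compounds shown leave open whether a chain ending in an amine or a carboxylic acid at this place would read apart from the plain chains. They also do not show how an ethyl chain, or a phenoxy group without its methyl, would compare on the shared core.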